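From compound 2 to compound 3: one added ethyl

This account rests on a few compounds, and the source may have more. Where it says the series, first, only, none or still open, it means among the compounds named here.

Measured in a functional assay on KG-1 cells (Homo sapiens) for inhibition, read by MTT assay, with a stated time of 48 h; on this read-out lower numbers stand for stronger inhibition and higher numbers for weaker inhibition:
Compound 1 `O=C(CCCOc1no[n+]([O-])c1S(=O)(=O)c1ccccc1)NO` gives 1480 nM
Compound 2 `CC(C)(COc1no[n+]([O-])c1S(=O)(=O)c1ccccc1)C(=O)NO` gives 6080 nM

Of these two compounds, compound 2 shows the higher number, which means the weaker inhibition. Compound 3 `CCCC(C)(COc1no[n+]([O-])c1S(=O)(=O)c1ccccc1)C(=O)NO` is not yet measured and differs from compound 2 by ethyl in place of hydrogen on a saturated chain carbon, two bonds along the chain from a carbonyl carbon. It carries ethyl in place of hydrogen on a saturated chain carbon, two bonds along the chain from a carbonyl carbon. For the measured compounds named here, only one measured step exists, a 4.1-fold higher number from compound 1 to compound 2 (0.61 log units; beyond the scatter), and it is a different change, so it offers weak guidance. The expected result is a 1.1-fold higher number from compound 2 to compound 3 (0.03 log units; within the scatter) and thus no step beyond the scatter. For compound 3 the estimate is 6500 nM with an expected range from 2200 nM to 18000 nM as its bounds.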

Compound 3, half-maximal inhibitory concentration: 4060 nM
Beside the measured number, compound 3's estimate is 1.6-fold (0.20 log units) above it, and the stated range covers the measured number.
By their numbers in this assay, from the lowest: compound 1; then compounds 3 and 2 (each within the scatter of the next).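

In this assay, ethyl in place of hydrogen on a saturated chain carbon, two bonds along the chain from a carbonyl carbon, gives a 1.5-fold lower number from compound 2 to compound 3 (0.18 log units; within the scatter). The earlier compounds shown here did not show this: at this position, methyl to propyl leaves the two compounds indistinguishable on this read-out. Nothing available here explains this result. The compounds shown leave open how a longer chain, a carboxylic acid or an amine at this carbon would read. They also leave open whether a phenyl group there would stay within the scatter of compound 2.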